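This account rests on a few compounds, and the source may have more. Where it says the series, first, only, none or still open, it means among the compounds named here.

Compound 1 `CC(C)=CCOc1cc(Nc2ncnc(Cl)n2)ccc1Cl` gives 45000 nM in an ADME assay on MT2 cells (Homo sapiens) for cytotoxicity; a higher number here means that more compound is tolerated, a lower number that less compound is tolerated. Compound 2 `CC(C)=CCOc1cc(Nc2ncnc(N)n2)ccc1Cl` gives 48000 nM in this assay, and the step is a 1.1-fold higher number from compound 1 to compound 2 (0.03 log units; within the scatter). Compound 3 `CC(C)=CCOc1cc(Nc2ncnc(Cl)n2)ccc1C#N` reaches only a limit of the assay, > 100000 nM, in this assay. That value sits at the limit of > 100000 nM in this assay, at which 1 of the 3 values shown sits, the top of the numbers shown. The step is an at least 2.2-fold higher number from compound 1 to compound 3 (0.34 log units; beyond the scatter). Compound 4 `CC(C)=CCOc1cc(Nc2ncnc(N)n2)ccc1C#N` carries the change (amino in place of chloro on an aromatic carbon). The same change on the chloro parent, a 1.1-fold higher number from compound 1 to compound 2 (0.03 log units; within the scatter), stayed within the scatter, so in this assay no step beyond the scatter is expected and the estimated step is a step that the limit leaves unreadable from compound 3 to compound 4. Compound 4 is therefore expected to give 120000 nM, with a range from 60000 nM to 300000 nM, most likely again reported only as a limit.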

Compound 4, half-maximal cytotoxic concentration: 200 nM
Estimate against measurement, compound 4: 600-fold (2.78 log units) above; measured number outside the range, below it.
By their numbers in this assay, from the lowest: compound 4; then compounds 1 and 2 (each within the scatter of the next). At a limit, above all of these: compound 3.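

In this assay, amino in place of chloro on the triazine carbon gives an at least 500-fold lower number from compound 3 to compound 4 (2.69 log units; beyond the scatter), a step read against the limit reached by compound 3. Cyano in place of chloro on the other aromatic carbon, with the amino group present, gives a 240-fold lower number from compound 2 to compound 4 (2.38 log units; beyond the scatter). The effect of the amino change therefore depends on the core carrying it, and only the pairing of amino with nitrile gives a low number here: the same change on two cores in this assay, a 1.1-fold higher number (0.03 log units; within the scatter) from compound 1 to compound 2 and an at least 500-fold lower number (2.69 log units; beyond the scatter) from compound 3 to compound 4, at least 530-fold (2.72 log units) apart, beyond the scatter of two such steps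

From the compounds shown here alone, it remains open whether a methylamino or hydroxyl group at this position on the nitrile core gives the same drop. Going by these compounds, it also remains open whether a trifluoromethyl group in place of the nitrile still pairs with amino in this way.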